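The source may report more compounds than this note shows. Statements on the series, on what has been measured and on what is new or still open speak of the compounds shown alone.

Compound 1 `CN1C[C@H](C(=O)Nc2ccc(Br)cc2)[C@@H](c2ccc(/C=C/C(=O)Nc3ccccc3N)cc2)C1` gives 3 mL/min/kg in an in vitro ADME assay on microsomes from liver (Homo sapiens) for pharmacokinetics, read by LC-MS, with a stated time of 10 min, tested at 1 uM; a lower number here means slower removal, a higher number faster removal of the compound. Compound 2 `CN1C[C@H](C(=O)Nc2cccc(Cl)c2)[C@@H](c2ccc(/C=C/C(=O)Nc3ccccc3N)cc2)C1` gives 7 mL/min/kg in this assay.

Compound 2 stands highest of the two numbers in this assay; its nearest neighbour, compound 1, shows a 2.3-fold higher number from compound 1 to compound 2 (0.37 log units; beyond the scatter). Compound 3 `CN1C[C@H](C(=O)Nc2ccc(Cl)cn2)[C@@H](c2ccc(/C=C/C(=O)Nc3ccccc3N)cc2)C1` carries 5-chloropyridin-2-yl in place of 3-chlorophenyl on an amide-type nitrogen. No measured step exchanges a carbon ring for one with a hetero atom, so the only step shown, from compound 1 to compound 2, bears on it indirectly at most, and it was modest. For compound 3 the step is therefore expected to stay within the scatter, a 1.4-fold lower number from compound 2 to compound 3 (0.15 log units; within the scatter). Compound 3 is estimated at 5 mL/min/kg, ranging from 2.5 mL/min/kg to 10 mL/min/kg.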

Compound 3, clearance: 13 mL/min/kg
Beside the measured number, compound 3's estimate is 2.6-fold (0.41 log units) below it; the whole stated range lies below it.
By their numbers in this assay, from the lowest: compound 1; then compounds 2 and 3 (each within the scatter of the next).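

In this assay, the nitrogen in the ring of the 5-chloropyridin-2-yl group leaves no reading beyond the scatter against the 3-chlorophenyl group (a 1.9-fold higher number from compound 2 to compound 3 (0.27 log units; within the scatter)). Against the 4-bromophenyl group, the same exchange on the amide-type nitrogen does go beyond the scatter (a 4.3-fold higher number from compound 1 to compound 3 (0.64 log units; beyond the scatter)), so compound 1 stands apart from both chlorine-bearing compounds at this position. No measurement at hand explains these steps. Still open, from the compounds shown here alone, is how a 5-bromopyridin-2-yl group, or a phenyl ring carrying an amine or a carboxylic acid, would read on this amide-type nitrogen.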